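This account rests on a few compounds, and the source may have more. Where it says the series, first, only, none or still open, it means among the compounds named here.

In a physicochemical assay for lipophilicity, using the shake flask method, in phosphate buffer, measured as octanol-water partition, with a stated time of 30 min, at pH 7.4 (on this read-out lower numbers stand for lower lipophilicity and higher numbers for higher lipophilicity), three compounds that share one core have been measured. Compound 1 `O=C(Nc1cnc(NCc2c(F)ccc3c2CCO3)n2cnnc12)c1ccccc1`, which carries benzamido, gives 3. Compound 2 `C[C@H]1CC(=O)N(c2cnc(NCc3c(F)ccc4c3CCO4)n3cnnc23)C1`, which carries 4-methyl-2-oxopyrrolidin-1-yl, gives 1.8. Compound 3 `O=C1CCCN1c1cnc(NCc2c(F)ccc3c2CCO3)n2cnnc12`, which carries 2-oxopyrrolidin-1-yl, gives 1.3, the lowest of the three numbers.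

Compound 4 `Fc1ccc2c(c1CNc1ncc(Nc3ccccc3)c3nncn13)CCO2` has not yet been measured. It has anilino in place of 2-oxopyrrolidin-1-yl on an aromatic carbon.

The most relevant measured change is the one between benzamido and 2-oxopyrrolidin-1-yl on that same carbon, which gave a number 1.70 log units lower from compound 1 to compound 3 (beyond the scatter), a large step. The change to the methylated ring gave a number 1.20 log units lower from compound 1 to compound 2 (beyond the scatter), also large, while removing the methyl gave a number 0.50 log units lower from compound 2 to compound 3 (beyond the scatter), a modest step.

Anilino, like the benzamido of compound 1, brings a six-membered aromatic ring of carbon only, so most of the step seen with compound 1 is expected to return in the upward direction. The expected change is a number 1.60 log units higher from compound 3 to compound 4 (beyond the scatter). For compound 4 the estimated value is 2.9, with an expected range from 2.4 to 3.4.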

Compound 4, distribution coefficient: 3.3
For compound 4 the middle estimate is 0.40 log units below the measured one; low and high end bracket the measured number.
By their numbers in this assay, from the lowest: compound 3; then compound 2; then compounds 1 and 4 (each within the scatter of the next).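

In this assay, anilino on this aromatic carbon gives a number 2.00 log units higher from compound 3 to compound 4 (beyond the scatter), and in place of 4-methyl-2-oxopyrrolidin-1-yl it gives a number 1.50 log units higher from compound 2 to compound 4 (beyond the scatter). The earlier compounds shown here showed only that benzamido and the two 2-oxopyrrolidin-1-yl groups differ, and that comparison could not separate the six-membered aromatic ring from the carbonyl attached to it. Phenyl in place of benzoyl on the nitrogen now gives a number 0.30 log units higher from compound 1 to compound 4 (within the scatter), so the read-out does not tell anilino from benzamido at this position, and the carbonyl of benzamido makes no difference beyond the scatter.

Nothing available explains the size of these steps. On these data alone, it remains open whether cyclohexylamino, with a saturated ring on the same nitrogen, or pyridin-2-ylamino, with a ring nitrogen, would stay with compound 4 in this read-out.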